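The source may hold more compounds than are shown below. What is called first, only, known or untested is meant among the compounds shown, and "the series" means these compounds.

Measured compounds:
compound 1 `CC(C(=O)N1CCC(F)(F)CC1)N1CCN(S(=O)(=O)c2ccc(C(C)(C)C)cc2)CC1`: > 40000 nM, a limit of the assay
compound 2 `CC1CCN(C(=O)C(C)N2CCN(S(=O)(=O)c3ccc(C(C)(C)C)cc3)CC2)CC1`: > 40000 nM, a limit of the assay
compound 3 `CC(C(=O)N1CCc2ccccc2C1)N1CCN(S(=O)(=O)c2ccc(C(C)(C)C)cc2)CC1`: 29000 nM

Compound 3 is the only one of the three that gives a number in an ADME assay on HepG2 cells (Homo sapiens) for inhibition, with a stated time of 48 h; a higher number here means that more compound is needed for the effect, a lower number that less compound is needed; the other two values are the limit of > 40000 nM in this assay, at which 2 of the 3 values shown sit. The two steps leading to it, an at least 1.3-fold lower number from compound 1 to compound 3 (0.13 log units; that floor lies within the scatter) and an at least 1.3-fold lower number from compound 2 to compound 3 (0.13 log units; that floor lies within the scatter), have floors within the scatter, and both exchange the whole ring on the carbonyl carbon. Compound 4 `CC(C(=O)N1CCc2ccccc2C1C)N1CCN(S(=O)(=O)c2ccc(C(C)(C)C)cc2)CC1` differs from compound 3 by methyl in place of hydrogen on a saturated ring carbon. Among the compounds with values here, none of the measured steps touches that ring carbon, so they give no guidance on this change, and no step beyond the scatter is expected. The estimate for compound 4 is 29000 nM, with a range from 12000 nM to 70000 nM. That estimate means an expected no change at the digits printed from compound 3 to compound 4 (within the scatter).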

Compound 4, half-maximal effective concentration: 28000 nM
Compound 4: middle estimate off by 1.0-fold (0.02 log units), on the high side; measured number inside the range.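

The new compound shows that this saturated ring carbon, next to the ring nitrogen, takes a methyl without a step beyond the scatter in this assay (a 1.0-fold lower number from compound 3 to compound 4 (0.02 log units; within the scatter)). Going by these compounds, the steps from the two limit compounds (an at least 1.4-fold lower number from compound 2 to compound 4 (0.15 log units; that floor lies within the scatter); an at least 1.4-fold lower number from compound 1 to compound 4 (0.15 log units; that floor lies within the scatter)) have floors that also lie within the scatter, and their true sizes stay unknown: the limit of > 40000 nM in this assay, at which 2 of the 4 values shown sit.

On these data alone, whether ethyl or a carboxylic acid on this ring carbon would shift the number in this assay remains open.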